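Swapping the amine on the carbonyl of compound 2

The source may report more compounds than this note shows. Statements on the series, on what has been measured and on what is new or still open speak of the compounds shown alone.

Three compounds share one core and differ only in the group attached to a carbonyl carbon. Compound 1 `Nc1sc(-c2ccc(Cl)cc2)c(-c2ccc(Cl)cc2)c1C(=O)N1CCCC1` carries pyrrolidin-1-yl there and in a functional assay on PC-3 cells (Homo sapiens) for inhibition, read by sulforhodamine B assay, with a stated time of 72 h (on this read-out lower numbers stand for stronger inhibition and higher numbers for weaker inhibition), compound 1 gives 6220 nM. Compound 2 `CN1CCN(C(=O)c2c(N)sc(-c3ccc(Cl)cc3)c2-c2ccc(Cl)cc2)CC1` carries 4-methylpiperazin-1-yl; in this assay compound 2 gives 13100 nM, the highest of the three numbers, with a 2.1-fold higher number from compound 1 to compound 2 (0.32 log units; beyond the scatter). Compound 3 `CC1CN(C(=O)c2c(N)sc(-c3ccc(Cl)cc3)c2-c2ccc(Cl)cc2)CCN1` carries 3-methylpiperazin-1-yl and in this assay compound 3 gives 7210 nM; the steps of a 1.2-fold higher number from compound 1 to compound 3 (0.06 log units; within the scatter) and a 1.8-fold lower number from compound 2 to compound 3 (0.26 log units; within the scatter) stay inside the scatter.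

Compound 4 `CCCCNC(=O)c1c(N)sc(-c2ccc(Cl)cc2)c1-c1ccc(Cl)cc1` is not yet measured. It differs from compound 2 in one place: butylamino in place of 4-methylpiperazin-1-yl on a carbonyl carbon. Among the compounds with values here, no measured step opens the ring in this way; the three known changes only swap one ring for another, and they move the number little. Since compound 2 stands highest, a modest drop back toward compound 1 and compound 3 is the reasonable expectation, so the step of a 1.6-fold lower number from compound 2 to compound 4 (0.21 log units; within the scatter) is estimated as small and possibly within the scatter. For compound 4 the expected value in this assay is 8000 nM, within a range from 2500 nM to 25000 nM.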

Compound 4, half-maximal inhibitory concentration: 17800 nM
Compound 4: the middle estimate sits 2.2-fold (0.35 log units) below what was measured; low and high end bracket the measured number.
By their numbers in this assay, from the lowest: compounds 1, 3, 2 and 4 (each within the scatter of the next, the first and the last beyond it).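

Replacing the ring with an open chain on this carbonyl carbon gives a step that stays inside the scatter in this assay (a 1.4-fold higher number from compound 2 to compound 4 (0.13 log units; within the scatter)), so butylamino and 4-methylpiperazin-1-yl cannot be told apart here. The same chain does separate from the other two ring amines, though only modestly (a 2.5-fold higher number from compound 3 to compound 4 (0.39 log units; beyond the scatter); a 2.9-fold higher number from compound 1 to compound 4 (0.46 log units; beyond the scatter)). A ring on the carbonyl is therefore not required to keep a number of this order, yet neither the chain nor any ring shown gives more than a modest step at this place.

Nothing measured alongside these numbers explains the steps. Going by these compounds, whether a shorter chain such as ethylamino, a butyl chain ending in a carboxylic acid, or a piperazine without a methyl group would move the number further remains open.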